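A few compounds are considered here, and "the series" means these few. Any claim that something is new, unique, unknown or untested is made for them only; others in the source may bear on it.

Working notes on the series. In an ADME assay on ECV-304 cells (Homo sapiens) for cytotoxicity, read by MTT assay, with a stated time of 72 h (on this read-out lower numbers stand for stronger inhibition and higher numbers for weaker inhibition), compound 1 (`COc1ccc(C2=C(c3cc(OC)c(OC)c(OC)c3)C(=O)CC2O[SiH2]C(C)(C)C)cc1OC`) gives > 100 ug/mL, which is a limit and not a number. Compound 2 (`COc1ccc(C2=C(c3cc(OC)c(OC)c(OC)c3)C(=O)C(O[SiH2]C(C)(C)C)C2)cc1OC(C)C`) also gives a limit, > 100 ug/mL. Compound 3 (`COc1cc(C2=C(c3ccc(SC)cc3)CC(O[SiH2]C(C)(C)C)C2=O)cc(OC)c1OC`) likewise gives a limit, > 100 ug/mL. The next entry, compound 4 (`COc1ccc(C2=C(c3cc(OC)c(OC)c(OC)c3)C(=O)CC2O[SiH2]C(C)(C)C)cc1O`), differs from compound 1 by hydrogen in place of methyl on an oxygen on an aromatic ring, turning 3,4-dimethoxyphenyl into 3-hydroxy-4-methoxyphenyl.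

Among the compounds with values here, the only measured step is a step that the two limits leave unreadable from compound 2 to compound 3, and it involves a different change, so it gives no size to carry over. Because the limit of > 100 ug/mL in this assay, at which 3 of the 3 values shown sit, no measured step sizes this change, and the expectation rests on little. Compound 4 is expected to remain weak in this assay, with a move to stronger inhibition possible but unsupported by any measured step, and a further limit is a real possibility. The expected change is an at least 2.0-fold lower number from compound 1 to compound 4 (0.30 log units; that floor lies within the scatter). For compound 4 the estimated value is 50 ug/mL, with an expected range of 3 ug/mL to 200 ug/mL.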

Compound 4, half-maximal inhibitory concentration: 30 ug/mL
For compound 4 the middle estimate is 1.7-fold (0.22 log units) above the measured one; the measured number falls inside the stated range.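

In this assay, hydrogen in place of methyl on an oxygen on an aromatic ring gives an at least 3.3-fold lower number from compound 1 to compound 4 (0.52 log units; beyond the scatter). Within the data shown here, compound 4 gives 30 ug/mL, the only number so far. Among these compounds, the change from 3,4-dimethoxyphenyl to 3-hydroxy-4-methoxyphenyl thus shows that a single change at this position can move the read-out off the limit, which the earlier compounds did not show. This step remains a floor and not a full size, and the series still rests mostly on limits: the limit of > 100 ug/mL in this assay, at which 3 of the 4 values shown sit.

Still open, from the compounds shown here alone, is whether hydroxy itself is what counts at this position, or whether an amine or a carboxylic acid in the same place would give a similar read-out. Also open, going by these compounds, is whether the same change on the other methoxy groups of compound 1 would give a step of similar size.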